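From cycloheptyl to cyclohexylmethyl in a cytotoxic series

The compounds below may be only part of what the source reports. "The series", "measured", "known", "first", "only" and "open" are said of these compounds alone.

Three measured compounds share one core and differ in a single group: compound 1 `O=C1Nc2c(ccc(F)c2F)C1(c1ccc(O)cc1)c1cccs1` carries thiophen-2-yl, compound 2 `O=C1Nc2c(ccc(F)c2F)C1(c1ccc(O)cc1)C1CCCC1` carries cyclopentyl and compound 3 `O=C1Nc2c(ccc(F)c2F)C1(c1ccc(O)cc1)C1CCCCCC1` carries cycloheptyl. In a functional assay on MCF7 cells (Homo sapiens) for cytotoxicity, read by WST assay, with a stated time of 72 h (a higher number here means a weaker inhibitor, a lower number a stronger inhibitor), compound 3 stands lowest at 1.2 nM among the three, while compound 2 gives 12 nM and compound 1 gives 82 nM on the same scale.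

Compound 4 `O=C1Nc2c(ccc(F)c2F)C1(CC1CCCCC1)c1ccc(O)cc1` has not yet been measured. It has cyclohexylmethyl in place of cycloheptyl on a saturated ring carbon. Among the measured compounds shown here, no measured step matches this change directly, but the same position has proved sensitive. The ring change alone gave a 10-fold lower number from compound 2 to compound 3 (1.00 log units; beyond the scatter) in this series, and the other changes gave a 6.8-fold lower number from compound 1 to compound 2 (0.83 log units; beyond the scatter) and a 68-fold lower number from compound 1 to compound 3 (1.83 log units; beyond the scatter) at that carbon. For the measured compounds named here, with compound 3 at 1.2 nM as the lowest number so far, a rise is more likely than a further fall. The expected change is a 5.0-fold higher number from compound 3 to compound 4 (0.70 log units; beyond the scatter) toward a weaker inhibitor, an estimate of modest size. Compound 4 is estimated at 6 nM with an expected range of 1.2 nM to 30 nM in this assay when measured.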

Compound 4, half-maximal inhibitory concentration: 102 nM
Estimate against measurement, compound 4: 17-fold (1.23 log units) below, and the stated range ends below it.
By their numbers in this assay, from the lowest: compound 3; then compound 2; then compounds 1 and 4 (each within the scatter of the next).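

In this assay, cyclohexylmethyl in place of cycloheptyl gave an 85-fold higher number from compound 3 to compound 4 (1.93 log units; beyond the scatter) with the same count of carbon atoms, so this position responds to how those carbons are joined and not to their number alone. The same group set against cyclopentyl gave an 8.5-fold higher number from compound 2 to compound 4 (0.93 log units; beyond the scatter) and against thiophen-2-yl gave a 1.2-fold higher number from compound 1 to compound 4 (0.09 log units; within the scatter), which places both saturated rings joined straight to the ring carbon on the stronger side of compound 4, while compound 1, with its thiophen-2-yl, goes against that pattern. Nothing available here explains these differences.

As far as these compounds go, whether plain cyclohexyl would stand with cyclopentyl and cycloheptyl or with compound 4 remains open. So does the effect of a longer link, as in cyclohexylethyl.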